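The source may hold more compounds than are shown below. What is called first, only, known or untested is meant among the compounds shown, and "the series" means these compounds.

Working notes on the series. Compound 1 `O=c1[nH]c(=O)n(CCC(CO)CO)cc1C#Cc1ccc(Br)cc1` carries a 4-bromophenyl on the triple-bonded carbon, and in a functional assay on SW-620 cells (Homo sapiens) for antiproliferative activity, read by MTT assay, with a stated time of 72 h (a higher number here means a weaker inhibitor, a lower number a stronger inhibitor), compound 1 reaches only the assay limit, > 100000 nM. Compound 2 `CCCCCC#Cc1cn(CCC(CO)CO)c(=O)[nH]c1=O` likewise reaches only the limit in this assay, giving > 100000 nM. Compound 3 `CCCCCCCCC#Cc1cn(CCC(CO)CO)c(=O)[nH]c1=O` also stands at the limit in this assay, with > 100000 nM. All three values sit at the limit of > 100000 nM in this assay, at which 3 of the 3 values shown sit, so the steps a step that the two limits leave unreadable from compound 1 to compound 2, a step that the two limits leave unreadable from compound 1 to compound 3 and a step that the two limits leave unreadable from compound 2 to compound 3 cannot be sized. Compound 4 `O=c1[nH]c(=O)n(CCC(CO)CO)cc1C#CCCCCl` differs from compound 3 by chloro in place of pentyl on a saturated chain carbon, three bonds along the chain from a triple-bonded carbon. Among the measured compounds shown here, no measured step has a readable size, so nothing shows whether this change moves this assay at all. Compound 4 is therefore expected to sit near the limit as well, estimated at 200000 nM (range 50000 nM to 1000000 nM). This amounts to an expected step that the limit leaves unreadable from compound 3 to compound 4.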

Compound 4, half-maximal inhibitory concentration: > 100000 nM
Compound 4 ended at the assay's limit; the forecaster's own chance of this, stated with the estimate: 80%; the middle value lies beyond the limit too.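

No step can be read for compound 1, compound 2, compound 3 or compound 4, since every value in this assay stands at a limit: the limit of > 100000 nM in this assay, at which 4 of the 4 values shown sit.

The compounds shown leave open whether any change to the group on the triple-bonded carbon moves this read-out.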